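Ethyl in Place of Hydroxy: An Untested Step

The source may hold more compounds than are shown below. What is called first, only, known or untested is meant among the compounds shown, and "the series" means these compounds.

Compound 1 `CC1CC/C(=N\Nc2ccccc2Cl)c2ncc(C(=O)O)c(=O)n21`: > 1000 umol/kg
Compound 2 `CC1CC/C(=N\Nc2ccc(O)cc2)c2ncc(C(=O)O)c(=O)n21`: > 100 umol/kg

In a functional assay on the whole organism for inhibition, with Rattus norvegicus as the target (on this read-out lower numbers stand for an effect already at smaller amounts and higher numbers for an effect only at larger amounts of compound), compound 1 gives > 1000 umol/kg, a limit of the measurement and not a number. Compound 2 gives > 100 umol/kg in this assay, again a limit rather than a number, so compound 2 stands at the limit of > 100 umol/kg in this assay, at which 1 of the 2 values shown sits. Among the compounds with values here, the only measured step, a step that the two limits leave unreadable from compound 1 to compound 2, is thus of unreadable size. Compound 3 `CCc1ccc(N/N=C2\CCC(C)n3c2ncc(C(=O)O)c3=O)cc1` differs from compound 2 by ethyl in place of hydroxy on an aromatic carbon. Within the data shown here, no measured step bears on this change, so no direction beyond the scatter is expected. Compound 3 is expected to give 200 umol/kg, between 50 umol/kg and 2000 umol/kg. The expected step that the limit leaves unreadable from compound 2 to compound 3 is therefore small.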

Compound 3, dose for 50% inhibition: > 1000 umol/kg
Compound 3 was reported as a limit (the forecaster's own chance of this, stated with the estimate: 75%); middle value at least 5.0-fold (0.69 log units) away from the limit.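

Within the data shown here, compound 1, compound 2 and compound 3 are all reported only as limits, so no step between them can be read. The compounds shown leave open what dose each needs in this assay, and whether 4-ethylphenyl and 4-hydroxyphenyl differ at all.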